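Moving the piperidine methyl from compound 3 to compound 4

The compounds below may be only part of what the source reports. "The series", "measured", "known", "first", "only" and "open" are said of these compounds alone.

In an ADME assay on MT4 cells (Homo sapiens) for cytotoxicity, read by MTT assay, with a stated time of 4 days (a higher number here means that more compound is tolerated, a lower number that less compound is tolerated), compound 1 `Cc1c(Cc2c(F)cccc2F)nc(N2CCC(C)CC2)[nH]c1=O` gives > 75000 nM, which is a limit of the assay and not a number. Compound 2 `CCN(C)c1nc(C(C)c2c(F)cccc2F)c(C)c(=O)[nH]1` gives a true number, 81000 nM. Compound 3 `Cc1c(C(C)c2c(F)cccc2F)nc(N2CCCC(C)C2)[nH]c1=O` gives > 72000 nM, again only a limit. Compound 3 therefore has no numerical position in the series.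

Compound 4 `Cc1c(C(C)c2c(F)cccc2F)nc(N2CCC(C)CC2)[nH]c1=O` has the same atoms as compound 3, joined differently: 4-methylpiperidin-1-yl in place of 3-methylpiperidin-1-yl on an aromatic carbon. The change is 4-methylpiperidin-1-yl in place of 3-methylpiperidin-1-yl on an aromatic carbon. Among the measured compounds shown here, the only measured step bearing on it is a step that the limit leaves unreadable from compound 2 to compound 3, so no step beyond the scatter is expected in this assay. The expected size is a step that the limit leaves unreadable from compound 3 to compound 4. For compound 4 the estimate is 80000 nM, with an expected range of 45000 nM to 140000 nM.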

Compound 4, half-maximal cytotoxic concentration: 54000 nM
The estimate for compound 4 lay 1.5-fold (0.17 log units) above the measured number, within the range that was stated.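

In this assay, compound 4 gives this position a number with a methylpiperidine in place, where compound 3 carries only a limit of the assay. Moving the methyl gives an at least 1.3-fold lower number from compound 3 to compound 4 (0.12 log units; that floor lies within the scatter), and 4-methylpiperidin-1-yl against ethyl(methyl)amino gives a 1.5-fold lower number from compound 2 to compound 4 (0.18 log units; within the scatter), so neither change is shown to shift the tolerated concentration. Methyl on the chain carbon bound to two aromatic carbons gives an at least 1.3-fold lower number from compound 1 to compound 4 (0.14 log units; that floor lies within the scatter); this step and the first are floors set by limits.

From the compounds shown here alone, whether a morpholine at this position, or a carboxylic acid on the piperidine ring, would stay within the scatter remains open.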